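The source may hold more compounds than are shown below. What is called first, only, known or untested is meant among the compounds shown, and "the series" means these compounds.

Four compounds share one core and differ only in the group on an amine nitrogen in a ring. Compound 1 `Cc1nc(-c2ccccc2)c(C(=O)N2CCN(c3cccc(C(N)=O)c3)CC2)o1` gives 71 nM in a functional assay on HL-60 cells (Homo sapiens) for inhibition, read by MTT assay, with a stated time of 72 h; a higher number here means a weaker inhibitor, a lower number a stronger inhibitor. Compound 2 `Cc1nc(-c2ccccc2)c(C(=O)N2CCN(c3ccc(C(F)(F)F)cc3)CC2)o1` gives > 1000 nM in this assay, which is a limit of the assay and not a number. The step of an at least 14-fold higher number from compound 1 to compound 2 (1.14 log units; beyond the scatter) is a large weakening. Compound 3 `CC(=O)c1ccc(N2CCN(C(=O)c3oc(C)nc3-c3ccccc3)CC2)cc1` is reported in this assay as "not active" (no number reported), with no number given; of the three values shown, one sits at the limit of > 1000 nM in this assay, at which 1 of the 3 values shown sits. Compound 4 `Cc1nc(-c2ccccc2)c(C(=O)N2CCN(c3ccccc3)CC2)o1` differs from compound 3 by hydrogen in place of acetyl on an aromatic carbon. Within the data shown here, no measured step covers removing acetyl, and the one measured step changed another group, so it bears only loosely here. In this assay compound 4 is expected to give about 2000 nM, estimated between 300 nM and 20000 nM.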

Compound 4, half-maximal inhibitory concentration: 39.1 nM
Compound 4: middle estimate off by 51-fold (1.71 log units), on the high side, and the stated range ends above it.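

In this assay, replacing trifluoromethyl with hydrogen gives an at least 25-fold lower number from compound 2 to compound 4 (1.40 log units; beyond the scatter), so the plain phenyl group is enough for activity and the loss in compound 2 goes with the added group. Replacing carbamoyl with hydrogen gives a 1.8-fold lower number from compound 1 to compound 4 (0.26 log units; within the scatter), so carbamoyl is not needed for activity here. Compound 2 stands at a limit, not a number: the limit of > 1000 nM in this assay, at which 1 of the 4 values shown sits.

The compounds shown leave open whether a methyl group, a fluorine atom or an amine would be tolerated where trifluoromethyl sits. They also leave open whether 4-carbamoylphenyl would match 3-carbamoylphenyl.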